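Sulfonamide aryl swap in a tricyclic antiproliferative series

A few compounds are considered here, and "the series" means these few. Any claim that something is new, unique, unknown or untested is made for them only; others in the source may bear on it.

Three compounds sharing one core have been run through a functional assay on KB cells (Homo sapiens) for antiproliferative activity, read by MTT assay, with a stated time of 72 h; on this read-out lower numbers stand for stronger inhibition and higher numbers for weaker inhibition. Compound 1 `CN(C(=O)c1ccc(Cl)cc1)c1ccc2[nH]c(-c3n[nH]c4ccccc34)cc2n1` gives 630 nM. Compound 2 `CN(C(=O)c1ccc(Br)cc1)c1ccc2[nH]c(-c3n[nH]c4ccccc34)cc2n1`, which carries bromo in place of chloro on an aromatic carbon, gives 1780 nM, a shift described by a 2.8-fold higher number from compound 1 to compound 2 (0.45 log units; beyond the scatter). Compound 3 `Cc1ccc(S(=O)(=O)N(C)c2ccc3[nH]c(-c4n[nH]c5ccccc45)cc3n2)cc1` gives 9500 nM and is the least potent of the three: the steps of a 15-fold higher number from compound 1 to compound 3 (1.18 log units; beyond the scatter) and a 5.3-fold higher number from compound 2 to compound 3 (0.73 log units; beyond the scatter) both arise when a (4-methylphenyl)sulfonyl replaces the arylcarbonyl on the nitrogen on the aromatic ring.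

Compound 4 `COc1ccc(S(=O)(=O)N(C)c2ccc3[nH]c(-c4n[nH]c5ccccc45)cc3n2)cc1OC` keeps the sulfonamide of compound 3 and differs from it by 3,4-dimethoxyphenyl in place of 4-methylphenyl on a sulfonyl sulfur. For the measured compounds named here, none of the three measured steps touches the aryl group on the sulfonyl sulfur; the only substituent change on record, from compound 1 to compound 2, sits on the carbonyl side of a different linker and was modest. Going by the values given here, there is thus no direct precedent, and compound 4 is expected to stay close to compound 3, with a step of a 1.1-fold lower number from compound 3 to compound 4 (0.02 log units; within the scatter) that may not exceed the scatter. Compound 4 is accordingly estimated at 9000 nM in this assay, within a range from 3000 nM to 30000 nM.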

Compound 4, half-maximal inhibitory concentration: 10100 nM
Compound 4: the middle estimate sits 1.1-fold (0.05 log units) below what was measured; low and high end bracket the measured number.
By their numbers in this assay, from the lowest: compound 1; then compound 2; then compounds 3 and 4 (each within the scatter of the next).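

For the compounds shown here, compound 4 gives the first reading of a change to the aryl group on the sulfonyl sulfur. In this assay, 3,4-dimethoxyphenyl in place of 4-methylphenyl gives a 1.1-fold higher number from compound 3 to compound 4 (0.03 log units; within the scatter) and so leaves the two sulfonamides indistinguishable. The entering group adds heavy atoms and brings hydrogen-bond acceptors where the leaving group has none, yet this exchange stays within the scatter, whereas each earlier step, from the halogen swap to the replacement of the arylcarbonyl by the sulfonyl, lies beyond it. No measurement at hand offers an explanation for this result.

Both aryl groups shown on the sulfonyl sulfur are six-membered aromatic rings of carbon only with no net charge, so it remains open whether a dimethylamino group or a carboxylic acid on that ring would move the number beyond the scatter. Also open, as far as these compounds go, is whether 3,4-dimethoxyphenyl on the carbonyl of compound 1, which gives 630 nM with its 4-chlorophenyl, would be accommodated as quietly as it is on the sulfonyl sulfur.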